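Benzyl in place of aryl on the ring amine nitrogen

A few compounds are considered here, and "the series" means these few. Any claim that something is new, unique, unknown or untested is made for them only; others in the source may bear on it.

compound 1 `CCCn1c(=O)[nH]c2nc(-c3ccc(S(=O)(=O)N4CCN(c5cccc(F)c5)CC4)cc3)[nH]c2c1=O`: 44%
compound 2 `CCCn1c(=O)[nH]c2nc(-c3ccc(S(=O)(=O)N4CCN(c5ccccc5Cl)CC4)cc3)[nH]c2c1=O`: 32%
compound 3 `CCCn1c(=O)[nH]c2nc(-c3ccc(S(=O)(=O)N4CCN(c5ccc(F)cc5)CC4)cc3)[nH]c2c1=O`: 38%

All three numbers come from an assay on CHO cells for displacement of a labelled ligand from adenosine receptor A3 (Homo sapiens), read by scintillation counting, with a stated time of 45 min, tested at 1 uM, in the presence of a further agent that is not named here; on this read-out higher numbers stand for more inhibition at the one concentration tested (going by the name of the read-out) and lower numbers for less inhibition. Compound 3 stands second highest of the three, but its gaps to compound 1 and to compound 2 are both within the scatter, so no order among the three can be drawn. The three compounds differ only in the aryl group on the ring amine nitrogen; the steps there were a number 12 percentage points lower from compound 1 to compound 2 (beyond the scatter), a number 6 percentage points lower from compound 1 to compound 3 (within the scatter) and a number 6 percentage points higher from compound 2 to compound 3 (within the scatter), the first modest, the other two within the scatter.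

Compound 4 `CCCn1c(=O)[nH]c2nc(-c3ccc(S(=O)(=O)N4CCN(Cc5cccc(Br)c5)CC4)cc3)[nH]c2c1=O` changes that position again: 3-bromobenzyl in place of 4-fluorophenyl on an amine nitrogen in a ring. Among the compounds with values here, this is the only change in this assay that exchanges the aryl group for a benzyl group, and no measured pair covers such a change; the measured steps show only that varying the group on this nitrogen has moved the read-out modestly at most. The expected step is a number 2 percentage points lower from compound 3 to compound 4 (within the scatter), none beyond the scatter, with wide uncertainty. Compound 4 is therefore estimated to give 36%, with a range from 15% to 57%.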

Compound 4, a percentage reported as inhibition, at one concentration (the size of the read-out at that concentration, not a potency): 23%
The estimate for compound 4 lay 13 percentage points above the measured number; the range from low to high includes it.
By their numbers in this assay, from the lowest: compounds 4, 2, 3 and 1 (each within the scatter of the next, the first and the last beyond it).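

The 3-bromobenzyl group on the ring amine nitrogen gives two steps beyond the scatter, though both are modest: a number 15 percentage points lower from compound 3 to compound 4 (beyond the scatter) and a number 21 percentage points lower from compound 1 to compound 4 (beyond the scatter). Against the 2-chlorophenyl group the picture differs, with a number 9 percentage points lower from compound 2 to compound 4 (within the scatter), so compound 2 and compound 4 cannot be separated in this assay, and the exchange of aryl for benzyl does not stand apart from all three aryl compounds. No measurement is available that accounts for these steps.

As far as these compounds go, compound 4 alters both the link to the nitrogen and the halogen, so the share of each in these steps remains open; a plain benzyl group on the same nitrogen would separate them. Also open, from the compounds shown here alone, is how this read-out responds to an amine or a carboxylic acid on the benzyl ring, or to a longer chain in place of the benzyl carbon.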